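Hydrazone aryl swap on the shared core: compound 2 to 4

The source may report more compounds than this note shows. Statements on the series, on what has been measured and on what is new or still open speak of the compounds shown alone.

Measured so far:
compound 1 `CN(C)CCn1cnnc1-c1cc(Oc2ccc(NC(=O)N/N=C/c3c[nH]c4ccccc34)cc2F)ccn1` gives 3620 nM in an ADME assay on WI-38 cells (Homo sapiens) for cytotoxicity, read by MTT assay, with a stated time of 72 h; on this read-out higher numbers stand for weaker inhibition and lower numbers for stronger inhibition
compound 2 `COc1ccc(OC)c(/C=N/NC(=O)Nc2ccc(Oc3ccnc(-c4nncn4CCN(C)C)c3)c(F)c2)c1` gives "not determined" (no result reported) in this assay
compound 3 `CN(C)CCn1cnnc1-c1cc(Oc2ccc(NC(=O)N/N=C/c3ccccc3O[N+](=O)[O-])cc2F)ccn1` gives 6860 nM in this assay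

Compound 2 `COc1ccc(OC)c(/C=N/NC(=O)Nc2ccc(Oc3ccnc(-c4nncn4CCN(C)C)c3)c(F)c2)c1` stands without a number in this assay; the two values shown come from compound 1 and compound 3, which differ only at the aryl group on the carbon double-bonded to nitrogen. Going by the values given here, that step, a 1.9-fold higher number from compound 1 to compound 3 (0.28 log units; within the scatter), is within the scatter, so the one measured aryl swap on this carbon moved nothing beyond noise.

Compound 4 `CN(C)CCn1cnnc1-c1cc(Oc2ccc(NC(=O)N/N=C/c3ccc(F)cc3)cc2F)ccn1` differs from compound 2 by 4-fluorophenyl in place of 2,5-dimethoxyphenyl on a carbon with a double bond to nitrogen. Among the compounds with values here, no step between compound 2 and compound 4 can be measured, and the only step bearing on a change at this carbon is the one from compound 1 to compound 3, which was flat. The expectation for compound 4 in this assay is therefore a value in the range of compound 1 and compound 3, with no direction beyond the scatter. Compound 4 is estimated at 5000 nM, expected to lie between 1500 nM and 16000 nM.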

Compound 4, half-maximal inhibitory concentration: 3980 nM
Estimate against measurement, compound 4: 1.3-fold (0.10 log units) above, and the stated range covers the measured number.
By their numbers in this assay, from the lowest: compounds 1, 4 and 3 (each within the scatter of the next).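

In this assay, the step of a 1.7-fold lower number from compound 3 to compound 4 (0.24 log units; within the scatter) and the step of a 1.1-fold higher number from compound 1 to compound 4 (0.04 log units; within the scatter) both lie within the scatter. One flat swap on the carbon with a double bond to nitrogen now becomes a flat set of three groups, as 4-fluorophenyl, with no hydrogen-bond donors or acceptors, reads the same as 1H-indol-3-yl and 2-(nitrooxy)phenyl.

Steps to compound 2 cannot be read, so the 2,5-dimethoxyphenyl group remains unplaced, and it is open whether an amine or a carboxylic acid on the phenyl ring at this carbon would move the number beyond the scatter. No evidence on any property of these groups accompanies the result.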